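The source may hold more compounds than are shown below. What is called first, only, known or untested is meant among the compounds shown, and "the series" means these compounds.

Measured compounds:
- compound 1, `O=C(Nc1cccc(-n2cc(-c3ccncc3)c(-c3ccc(Cl)c(O)c3)n2)c1)Nc1cccc(C(F)(F)F)c1`: 2230 nM
- compound 2, `COc1cc(-c2nn(-c3cccc(NC(=O)Nc4ccc(Cl)c(C(F)(F)F)c4)c3)cc2-c2ccncc2)ccc1Cl`: 1480 nM

Both values come from a functional assay on HOP-92 cells (Homo sapiens) for inhibition, read by sulforhodamine B assay, with a stated time of 48 h; a lower number here means a stronger inhibitor of growth, a higher number a weaker inhibitor of growth. Compound 2 gives the lower of the two numbers, but the nearest number, that of compound 1, lies within the usual scatter of it, so the two compounds cannot be told apart on these data. For the measured compounds named here, compound 1 and compound 2 differ in more than one place, and no single step between them is recorded; only their two values are known.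

Compound 3, `O=C(Nc1cccc(-n2cc(-c3ccncc3)c(-c3ccc(Cl)c(O)c3)n2)c1)Nc1ccc(Cl)c(C(F)(F)F)c1`, has not yet been measured in this assay. It differs from compound 2 in one place: hydrogen in place of methyl on an oxygen on an aromatic ring, that is, methoxy to hydroxy on the 4-chloro-3-methoxyphenyl ring, which becomes 4-chloro-3-hydroxyphenyl. Going by the values given here, no measured pair shows this change on its own. The expectation is a step of a 1.2-fold higher number from compound 2 to compound 3 (0.09 log units; within the scatter) from compound 2, no larger than the scatter, in either direction. Compound 3 is estimated at 1800 nM in this assay, with a range from 700 nM to 4500 nM.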

Compound 3, concentration for total growth inhibition: 1460 nM
Estimate against measurement, compound 3: 1.2-fold (0.09 log units) above; the range from low to high includes it.
By their numbers in this assay, from the lowest: compounds 3, 2 and 1 (each within the scatter of the next).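

Methoxy to hydroxy on the 4-chloro-3-methoxyphenyl ring can now be read on its own in this assay, and it gives a 1.0-fold lower number from compound 2 to compound 3 (0.01 log units; within the scatter), so this readout does not separate the two groups at this oxygen on the shared core. Chloro in place of hydrogen on an aromatic carbon, also a change in one place, gives a 1.5-fold lower number from compound 1 to compound 3 (0.18 log units; within the scatter), so this readout does not separate hydrogen and chloro there either. No supporting data bear on the size of these two steps.

Going by these compounds, whether an amine or a carboxylic acid in place of the hydroxy would give a step beyond the scatter stays open. The same holds for a longer chain on the oxygen in place of the methyl.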